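A Methoxyphenyl Sulfonamide Expected at the Assay Ceiling

A few compounds are considered here, and "the series" means these few. Any claim that something is new, unique, unknown or untested is made for them only; others in the source may bear on it.

Compound 1 `COC(=O)c1ccc(C2SCC(=O)N2c2ccc(N3CCN(Cc4cccc([N+](=O)[O-])c4)CC3)cn2)c(OC)c1` gives 68700 nM in a functional assay on K562 cells (Homo sapiens) for antiproliferative activity, read by MTT assay and trypan blue exclusion, with a stated time of 72 h; a higher number here means a weaker inhibitor, a lower number a stronger inhibitor.
Compound 2 `COC(=O)c1ccc(C2SCC(=O)N2c2ccc(N3CCN(Cc4ccc(Cl)c(Cl)c4)CC3)cn2)c(OC)c1` gives > 100000 nM in this assay, a limit of the assay.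
Compound 3 `COC(=O)c1ccc(C2SCC(=O)N2c2ccc(N3CCN(S(=O)(=O)c4cc(Cl)ccc4Cl)CC3)cn2)c(OC)c1` gives > 100000 nM in this assay, again a limit rather than a number.

Compound 3 therefore stands only at a limit, and (the limit of > 100000 nM in this assay, at which 2 of the 3 values shown sit). Compound 4 `COC(=O)c1ccc(C2SCC(=O)N2c2ccc(N3CCN(S(=O)(=O)c4ccc(OC)cc4)CC3)cn2)c(OC)c1` differs from it by 4-methoxyphenyl in place of 2,5-dichlorophenyl on a sulfonyl sulfur. The measured steps that touch this position are an at least 1.4-fold higher number from compound 1 to compound 3 (0.16 log units; that floor lies within the scatter) and a step that the two limits leave unreadable from compound 2 to compound 3; neither changes the aryl group on the sulfonyl sulfur, and both are floors or unreadable. Among the measured compounds shown here, no measured step therefore bears directly on the change, and no step beyond the scatter is expected in this assay. Compound 4 is estimated at 100000 nM, within 40000 nM to 300000 nM, which means an expected step of a number no higher from compound 3 to compound 4 (the limit leaves the size open).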

Compound 4, half-maximal inhibitory concentration: 54500 nM
Compound 4: middle estimate off by 1.8-fold (0.26 log units), on the high side; the range from low to high includes it.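

In this assay, 4-methoxyphenyl on the sulfonyl sulfur gives the only sulfonamide shown with a number rather than a limit, with an at least 1.8-fold lower number from compound 3 to compound 4 (0.26 log units; that floor lies within the scatter). The change from the 3,4-dichlorobenzyl group gives an at least 1.8-fold lower number from compound 2 to compound 4 (0.26 log units; that floor lies within the scatter), and this floor, like the previous one, rests on a limit of the assay. The change from the 3-nitrobenzyl group gives a 1.3-fold lower number from compound 1 to compound 4 (0.10 log units; within the scatter), so compound 4 is not separated from compound 1.

Going by these compounds, whether any aryl group on the sulfonyl sulfur moves the number beyond the scatter stays open. So does how a phenyl ring carrying an amine or a carboxylic acid would read there.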